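This account rests on a few compounds, and the source may have more. Where it says the series, first, only, none or still open, it means among the compounds named here.

Compound 1, `CCCCCCCCSCC1C2CCC(O2)C1C/C=C\CCCC(=O)O`, in a functional assay on a cell-free system (plasma) for inhibition of thromboxane A2 receptor (Homo sapiens); on this read-out lower numbers stand for stronger inhibition and higher numbers for weaker inhibition: 547000 nM.
Compound 2, `CCCCC(O)CSCC1C2CCC(O2)C1C/C=C\CCCC(=O)O`, in this assay: 19000 nM; 10000 nM (2 entries).
Compound 3, `CCC/C=C/CSCC1C2CCC(O2)C1C/C=C\CCCC(=O)O`, in this assay: 1300 nM.

Among these, compound 3 stands at the lowest of the two single numbers in this assay; its nearest neighbour is compound 1, and the step of a 420-fold lower number from compound 1 to compound 3 (2.62 log units; beyond the scatter) is the only one-place change measured here. Compound 2 has several entries the several entries of compound 2 in this assay, 19000 nM; 10000 nM (2 entries) and no single number, so its gap to compound 3 is not counted as a step. Compound 4, `CCC/C=C(\C)CSCC1C2CCC(O2)C1C/C=C\CCCC(=O)O`, has not been measured. It differs from compound 3 by a group of 6 heavy atoms (6 carbon; no ring) in place of a group of 5 heavy atoms (5 carbon; no ring), on a saturated chain carbon bound to a sulfur. For the measured compounds named here, the one measured step, a 420-fold lower number from compound 1 to compound 3 (2.62 log units; beyond the scatter), exchanged heptyl for the pent-1-en-1-yl group and was large, but no measured step compares two unsaturated groups of this kind, so it offers little guidance for the change at hand. With the double bond kept, compound 4 is therefore expected to give a step of a 1.1-fold lower number from compound 3 to compound 4 (0.03 log units; within the scatter), not reaching beyond the scatter. The estimate for compound 4 in this assay is 1200 nM, with a range from 400 nM to 4000 nM.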

Compound 4, half-maximal inhibitory concentration: 1100 nM
Estimate against measurement, compound 4: 1.1-fold (0.04 log units) above; the measured number falls inside the stated range.
By their numbers in this assay, from the lowest: compounds 4 and 3 (each within the scatter of the next); then compound 1.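

In this assay, a 1.2-fold lower number from compound 3 to compound 4 (0.07 log units; within the scatter) shows that, on a saturated chain carbon bound to a sulfur, a group of 6 heavy atoms can take the place of pent-1-en-1-yl with no difference beyond the scatter, so this position tolerates this change between two groups that each hold one double bond. The large step from heptyl is also no longer tied to pent-1-en-1-yl alone, since a 500-fold lower number from compound 1 to compound 4 (2.70 log units; beyond the scatter) is of the same large class as the earlier step to compound 3. Nothing in the data shown gives a reason for this result.

Both steps from compound 1 shorten the chain and introduce a double bond at once, so the two changes remain unseparated. As far as these compounds go, how an amine, a phenyl ring or a longer unsaturated chain would read at this place in this assay remains open.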